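The source may hold more compounds than are shown below. What is called first, only, known or untested is meant among the compounds shown, and "the series" means these compounds.

Measured in a functional assay on KYSE-410 cells (Homo sapiens) for antiproliferative activity, read by MTT assay, with a stated time of 72 h; a higher number here means a weaker inhibitor, a lower number a stronger inhibitor:
- compound 1 `O=C(Nc1cccc(F)c1)c1cc(=O)[nH]c2cc(-c3cccc(F)c3)ccc12`: 10900 nM
- compound 2 `O=C(Nc1cccc(F)c1)c1cc(=O)[nH]c2cc(-c3ccccc3F)ccc12`: > 20000 nM (a limit)
- compound 3 `Cc1ccc(-c2ccc3c(C(=O)Nc4cccc(F)c4)cc(=O)[nH]c3c2)cc1`: > 20000 nM (a limit)

Compound 3 gives no number and sits at the limit of > 20000 nM in this assay, at which 2 of the 3 values shown sit.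

Compound 4 `O=C(Nc1cccc(F)c1)c1cc(=O)[nH]c2cc(C3=CCOCC3)ccc12` changes the group on that same aromatic carbon: a group of 6 heavy atoms (5 carbon, 1 oxygen; one six-membered non-aromatic ring with 1 hetero atom) in place of a group of 7 heavy atoms (7 carbon; one six-membered aromatic ring of carbon only), on an aromatic carbon.

The nearest measured changes also fall at this carbon, but both swap one aromatic group for another. These are an at least 1.8-fold higher number from compound 1 to compound 2 (0.26 log units; that floor lies within the scatter) and an at least 1.8-fold higher number from compound 1 to compound 3 (0.26 log units; that floor lies within the scatter), each with a floor inside the scatter, while a step that the two limits leave unreadable from compound 2 to compound 3 cannot be sized. None of them covers a non-aromatic ring, so the expectation rests on compound 1 at 10900 nM as the only numerical anchor.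

The expected step is an at least 1.2-fold lower number from compound 3 to compound 4 (0.09 log units; that floor lies within the scatter), and no change beyond the scatter is expected. For compound 4 the estimate is 16000 nM, with an expected range of 7000 nM to 30000 nM.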

Compound 4, half-maximal inhibitory concentration: 12100 nM
Estimate against measurement, compound 4: 1.3-fold (0.12 log units) above; low and high end bracket the measured number.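

In this assay, a non-aromatic ring at this carbon gives a number that cannot be told apart from that of the 3-fluorophenyl group: a 1.1-fold higher number from compound 1 to compound 4 (0.05 log units; within the scatter). The other two steps are an at least 1.6-fold lower number from compound 3 to compound 4 (0.21 log units; that floor lies within the scatter) and an at least 1.6-fold lower number from compound 2 to compound 4 (0.21 log units; that floor lies within the scatter), so a measured number here does not depend on an aromatic ring at this carbon. Compounds 2 and 3 remain limits, not numbers: the limit of > 20000 nM in this assay, at which 2 of the 4 values shown sit.

No step shown lies clearly beyond the scatter. From the compounds shown here alone, whether a piperidine ring, a primary amine or a carboxylic acid at this carbon would shift the number remains open.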